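From 3,4-dichlorophenyl to 2,3-dichlorophenyl: working notes

The source may hold more compounds than are shown below. What is called first, only, known or untested is meant among the compounds shown, and "the series" means these compounds.

In a functional assay on A549 cells (Homo sapiens) for cytotoxicity, read by MTT assay, with a stated time of 72 h (on this read-out higher numbers stand for weaker inhibition and lower numbers for stronger inhibition), compound 1 `CNC(=O)c1cc(Oc2ccc(C3=NNC(c4ccc(C#N)cc4)C3)cc2)ccn1` gives 17400 nM, compound 2 `CNC(=O)c1cc(Oc2ccc(C3=NNC(c4ccc([N+](=O)[O-])cc4)C3)cc2)ccn1` gives 19500 nM and compound 3 `CNC(=O)c1cc(Oc2ccc(C3=NNC(c4ccc(Cl)c(Cl)c4)C3)cc2)ccn1` gives 10700 nM. Compound 3 lies within the scatter of both other compounds, so the three values form a single band.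

Compound 4 `CNC(=O)c1cc(Oc2ccc(C3=NNC(c4cccc(Cl)c4Cl)C3)cc2)ccn1` is still unmeasured. The structural change is 2,3-dichlorophenyl in place of 3,4-dichlorophenyl on a saturated ring carbon, with 2,3-dichlorophenyl in place of 3,4-dichlorophenyl on a saturated ring carbon.

Two measured steps replace the aromatic group at this carbon: a 1.6-fold lower number from compound 1 to compound 3 (0.21 log units; within the scatter) and a 1.8-fold lower number from compound 2 to compound 3 (0.26 log units; within the scatter). Both stay within the scatter, as does a 1.1-fold higher number from compound 1 to compound 2 (0.05 log units; within the scatter), which changes only the substituent on that aromatic group. Going by the values given here, none of these steps compares two dichlorophenyl isomers, so the series offers no direct precedent and no firm basis for a direction.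

No shift beyond the scatter is expected in this assay. The estimated step is a 1.1-fold higher number from compound 3 to compound 4 (0.05 log units; within the scatter). For compound 4, the estimated value is 12000 nM, with an expected range of 6500 nM to 22000 nM.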

Compound 4, half-maximal inhibitory concentration: 12100 nM
For compound 4 the middle estimate is 1.0-fold (0.00 log units) below the measured one; measured number inside the range.
By their numbers in this assay, from the lowest: compounds 3, 4, 1 and 2 (each within the scatter of the next).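

Working notes on the result: in this assay, exchanging 3,4-dichlorophenyl for 2,3-dichlorophenyl on this saturated ring carbon gives the only comparison of two dichlorophenyl isomers in the series (a 1.1-fold higher number from compound 3 to compound 4 (0.05 log units; within the scatter)), and the step stays within the scatter. Against the two singly substituted aromatic groups, 2,3-dichlorophenyl also stays within the scatter (a 1.6-fold lower number from compound 2 to compound 4 (0.21 log units; within the scatter); a 1.4-fold lower number from compound 1 to compound 4 (0.16 log units; within the scatter)), so the single band now holds all four compounds. No evidence is available that bears on this result.

The compounds shown leave open whether a carboxylic acid or a dimethylamino group on this aromatic ring, or a cyclohexyl ring in its place, would move the number beyond the scatter. Going by these compounds, what a change elsewhere in the shared core would do also stays open.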